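The source may hold more compounds than are shown below. What is called first, only, known or untested is meant among the compounds shown, and "the series" means these compounds.

Measured compounds:
Compound 1 `O=C(CCN1CCCC1)Nc1nc(-c2ccccc2)cs1`: 68.4%
Compound 2 `COc1ccc(-c2csc(NC(=O)CCN3CCCC3)n2)cc1`: 56.2%
Compound 3 `O=C(CCN1CCCC1)Nc1nccs1`: 64.1%

In a functional assay on the whole organism (strain AKR) for inhibition, with Rattus norvegicus as the target, read by paw edema, at a dose of 0.2 mmol/kg by the intraperitoneal route, in the presence of a further agent that is not named here (on this read-out higher numbers stand for more inhibition at the one dose given (going by the name of the read-out) and lower numbers for less inhibition), compound 1 gives 68.4%, the largest of the three numbers, though the step of a number 4.3 percentage points lower from compound 1 to compound 3 (within the scatter) stays within the scatter, while the step of a number 12.2 percentage points lower from compound 1 to compound 2 (beyond the scatter) goes beyond it. Compound 4 `O=C(CN1CCCC1)Nc1nc(-c2ccccc2)cs1` has not yet been measured. It differs from compound 1 in one place: pyrrolidin-1-yl in place of (pyrrolidin-1-yl)methyl on a saturated chain carbon bound to a carbonyl carbon. Among the measured compounds shown here, both measured steps change the aromatic part of the shared core, not the chain between the carbonyl and the pyrrolidine, so neither bears directly on this change; the one step that is beyond the scatter is modest. No step beyond the scatter is therefore expected. Compound 4 is estimated at 63%, with a range of 46% to 78%. That corresponds to an expected step of a number 5.4 percentage points lower from compound 1 to compound 4 (within the scatter).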

Compound 4, a percentage reported as inhibition, in the whole organism at one dose (the size of the read-out at that dose, not a potency): 49.2%
The estimate for compound 4 lay 13.8 percentage points above the measured number; measured number inside the range.
By their numbers in this assay, from the lowest: compounds 4, 2, 3 and 1 (each within the scatter of the next, the first and the last beyond it).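

Going from 2-(pyrrolidin-1-yl)ethyl to (pyrrolidin-1-yl)methyl on the saturated chain carbon bound to the carbonyl carbon gives a step (a number 19.2 percentage points lower from compound 1 to compound 4 (beyond the scatter)) in this assay and so shows that chain length matters at the one dose given. The earlier steps shown here changed only the aromatic part of the shared core, so they could not show this. Nothing available here explains the loss.

As far as these compounds go, whether a longer chain such as 3-(pyrrolidin-1-yl)propyl would give more or less inhibition remains open. So does whether the chain length matters equally with another amine, such as piperidine, in place of the pyrrolidine.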